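Changing the Aryl Group on the Carbonyl Carbon

A few compounds are considered here, and "the series" means these few. Any claim that something is new, unique, unknown or untested is made for them only; others in the source may bear on it.

- compound 1 `O=C(/C(=C\c1ccc(O)c([N+](=O)[O-])c1)SCc1ccc(Br)cc1)c1c(F)c(F)c(F)c(F)c1F` gives 10000 nM
- compound 2 `O=C(/C(=C\c1ccc(O)c([N+](=O)[O-])c1)SCc1ccc(Br)cc1)c1ccc(Cl)cc1Cl` gives 10000 nM

Both values come from a functional assay on DU-145 cells (Homo sapiens) for inhibition, read by trypan blue exclusion, with a stated time of 96 h (on this read-out higher numbers stand for weaker inhibition of growth and lower numbers for stronger inhibition of growth), and place compound 2 level with compound 1. Compound 3 `COc1ccc(C(=O)/C(=C\c2ccc(O)c([N+](=O)[O-])c2)SCc2ccc(Br)cc2)cc1` keeps the shared core but has 4-methoxyphenyl in place of 2,4-dichlorophenyl on a carbonyl carbon and still awaits measurement. Within the data shown here, only one measured step bears on this change. An exchange on the same carbonyl carbon gave no change at the digits printed from compound 1 to compound 2 (within the scatter) and so had no size beyond the scatter. Neither measured compound carries 4-methoxyphenyl, which makes this thin evidence and gives no direction. No clear shift is therefore expected in this assay and the estimated step is a 1.3-fold lower number from compound 2 to compound 3 (0.10 log units; within the scatter) at most a small one. For compound 3 the estimate is 8000 nM with an expected range of 3000 nM to 20000 nM around it.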

Compound 3, concentration for 50% growth inhibition: 10000 nM
For compound 3 the middle estimate is 1.3-fold (0.10 log units) below the measured one; the measured number falls inside the stated range.
By their numbers in this assay, from the lowest: compounds 1, 2 and 3 (each within the scatter of the next).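

In this assay, replacing 2,4-dichlorophenyl with 4-methoxyphenyl on a carbonyl carbon gives no change at the digits printed from compound 2 to compound 3 (within the scatter) and replacing 2,3,4,5,6-pentafluorophenyl with the same group gives no change at the digits printed from compound 1 to compound 3 (within the scatter) as well. The number therefore holds even when the ring on this carbon carries no halogen atoms and gains an oxygen and a hydrogen-bond acceptor, something the two halogen-bearing compounds alone could not show. Nothing available here offers a reason for this flat result.

From the compounds shown here alone, it remains open whether a ring carrying an amine or a carboxylic acid, or a plain alkyl chain in place of the ring, would shift the number at this carbon. Going by these compounds, it is also open whether this position would respond differently if the rest of the shared core were changed.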